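From compound 1 to compound 4 in a limit-bound series

The compounds below may be only part of what the source reports. "The series", "measured", "known", "first", "only" and "open" are said of these compounds alone.

In a functional assay on HepG2 cells (Homo sapiens) for antiproliferative activity, read by MTT assay, with a stated time of 72 h (a lower number here means a stronger inhibitor, a higher number a weaker inhibitor), compound 1 `COc1cccc(N2C(=O)COc3ccc(-c4cnc(Cl)c(NS(=O)(=O)c5ccc(F)cc5)c4)cc32)c1` gives > 40000 nM, a limit of the assay and not a number. Compound 2 `COc1cccc(N2C(=O)COc3ccc(-c4cnc(OC)c(NS(=O)(=O)c5ccc(F)cc5)c4)cc32)c1` gives > 40000 nM, also a limit. Compound 3 `Cc1ccc(N2C(=O)COc3ccc(-c4cnc5ccccc5c4)cc32)cc1` gives > 40000 nM, again a limit. Going by the values given here, the series so far therefore offers only (the limit of > 40000 nM in this assay, at which 3 of the 3 values shown sit), and compound 1 has no numerical position within it.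

Compound 4 `O=C1COc2ccc(-c3cnc(Cl)c(NS(=O)(=O)c4ccc(F)cc4)c3)cc2N1c1ccc(Cl)cc1` differs from compound 1 in one place: 4-chlorophenyl in place of 3-methoxyphenyl on an amide-type nitrogen in a ring. In words, this is 4-chlorophenyl in place of 3-methoxyphenyl on an amide-type nitrogen in a ring.

Among the compounds with values here, the only measured step is a step that the two limits leave unreadable from compound 1 to compound 2. It is a different change, methoxy in place of chloro on an aromatic carbon, and it gives no size to carry over. No measured step sizes the change to compound 4.

No step beyond the scatter is expected in this assay in either direction, and the estimated step is a number no higher from compound 1 to compound 4 (the limit leaves the size open). Compound 4 is expected at 40000 nM, with an estimated range of 15000 nM to 60000 nM.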

Compound 4, half-maximal inhibitory concentration: 33900 nM
The estimate for compound 4 lay 1.2-fold (0.07 log units) above the measured number; the range from low to high includes it.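

In this assay, going by these compounds alone, compound 4 gives 33900 nM, the only value shown that is a number and not a limit, so a change on the amide-type nitrogen has now produced a readable position. Placing 4-chlorophenyl there in place of 3-methoxyphenyl gives an at least 1.1-fold lower number from compound 1 to compound 4 (0.07 log units; that floor lies within the scatter), so the floor alone supports no claim of a real change, while the true size stays open. The rest of the series offers no numerical comparison: the limit of > 40000 nM in this assay, at which 3 of the 4 values shown sit.

The compounds shown leave open whether the step from the limit of compound 1 exceeds its floor. They also leave open how an aminophenyl or a carboxyphenyl group would read on this nitrogen with the rest of compound 4 kept unchanged.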